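A few compounds are considered here, and "the series" means these few. Any claim that something is new, unique, unknown or untested is made for them only; others in the source may bear on it.

Measured compounds in the series:

compound 1 `O=[N+]([O-])c1cc(OCc2ccccc2)ccc1CNc1cc(C(F)(F)F)cc2[nH]ncc12` — in an assay for inhibition of Tryptophan 2,3-dioxygenase (Homo sapiens), with stated times of 10 min and 60 min, tested at 10 uM (a lower number here means a weaker effect, a higher number a stronger effect of the compound at the concentration tested), compound 1 gives 49%
compound 2 `O=[N+]([O-])c1ccccc1CNc1cccc2[nH]ncc12` — in this assay compound 2 gives 45%
compound 3 `N#Cc1cc(NCc2ccccc2[N+](=O)[O-])c2cn[nH]c2c1` — in this assay compound 3 gives 22%

Compound 3 stands lowest of the three numbers. Its nearest neighbour is compound 2, whose number is higher by a step beyond the scatter; compound 1 is furthest, also beyond the scatter.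

The next compound, compound 4 `COC(=O)c1cc(NCc2ccccc2[N+](=O)[O-])c2cn[nH]c2c1`, differs from compound 3 in one place: methoxycarbonyl in place of cyano on an aromatic carbon

Among the compounds with values here, only one measured step touches the same place: a number 23 percentage points lower from compound 2 to compound 3 (beyond the scatter), in which cyano entered for hydrogen. Within the data shown here, no measured pair swaps cyano for methoxycarbonyl, so the size and direction of that exchange is unknown here; the one step at this position shows that a substituent there lowered the number, but it gives no basis for separating one substituent from another. Without a measured anchor for methoxycarbonyl, the working expectation is that compound 4 stays near compound 3, with no step beyond the scatter: the step from compound 3 to compound 4 is estimated as a number 3 percentage points higher from compound 3 to compound 4 (within the scatter).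

For compound 4 the estimated value in this assay is 25%, with an expected range from 5% to 45%.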

Compound 4, a percentage reported as inhibition, at one concentration (the size of the read-out at that concentration, not a potency): 16%
Estimate against measurement, compound 4: 9 percentage points above, and the stated range covers the measured number.
By their numbers in this assay, from the lowest: compounds 4 and 3 (each within the scatter of the next); then compounds 2 and 1 (each within the scatter of the next).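

In this assay, methoxycarbonyl in place of cyano on this aromatic carbon gives a number 6 percentage points lower from compound 3 to compound 4 (within the scatter), so the two groups are not told apart here, even though methoxycarbonyl carries 4 heavy atoms and 2 hydrogen-bond acceptors against 2 heavy atoms and 1 hydrogen-bond acceptor for cyano. Measured against hydrogen at the same place, the change gives a number 29 percentage points lower from compound 2 to compound 4 (beyond the scatter), and with a number 23 percentage points lower from compound 2 to compound 3 (beyond the scatter) this makes two different substituents that each stand beyond the scatter from compound 2, a pattern that rests on compound 2, compound 3 and compound 4 alone and that none of them goes against. Nothing measured in this series accounts for that shared drop.

Going by these compounds, whether the drop holds for every group at this place remains open, since a primary amine, a carboxylic acid, a methyl or a fluorine could either keep the number near that of compound 2 or follow compound 3 and compound 4. Compound 1 differs from these compounds in more than one place, so its number does not separate the effect of this position from that of its other changes.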